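Replacing nitro with cyano in compound 1

The source may report more compounds than this note shows. Statements on the series, on what has been measured and on what is new or still open speak of the compounds shown alone.

Compound 1 `N#C[Se]Cc1ccccc1[N+](=O)[O-]` gives 7100 nM
Compound 2 `CSc1ccc(C[Se]C#N)cc1` gives 17000 nM
Compound 3 `N#C[Se]Cc1ccc(C#N)cc1` gives 7970 nM

All three values come from an ADME assay on THP-1 cells (Homo sapiens) for cytotoxicity, read by trypan blue exclusion, with a stated time of 24 h (on this read-out lower numbers stand for stronger inhibition and higher numbers for weaker inhibition), and compound 1 stands within the scatter of compound 3, with both numbers lower than that of compound 2. Moving to compound 4 `N#C[Se]Cc1ccccc1C#N` puts cyano in place of nitro on an aromatic carbon. Within the data shown here, one measured step bears on this: a 2.1-fold lower number from compound 2 to compound 3 (0.33 log units; beyond the scatter) and it is modest. It also brings in cyano, but there methylsulfanyl leaves, not nitro, so it guides only indirectly. Compound 3 carries cyano and gives 7970 nM within the scatter of compound 1. The estimated 1.1-fold higher number from compound 1 to compound 4 (0.05 log units; within the scatter) is therefore expected to stay within the scatter. For compound 4 the expected value is 8000 nM (range 4000 nM to 16000 nM).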

Compound 4, half-maximal inhibitory concentration: 17100 nM
Beside the measured number, compound 4's estimate is 2.1-fold (0.33 log units) below it; measured number above the stated range.
By their numbers in this assay, from the lowest: compounds 1 and 3 (each within the scatter of the next); then compounds 2 and 4 (each within the scatter of the next).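

In this assay there is a 2.4-fold higher number from compound 1 to compound 4 (0.38 log units; beyond the scatter) when cyano replaces nitro on the aromatic carbon ortho to a group of 4 heavy atoms, so the swap is not neutral at this position. The earlier cyano step, with methylsulfanyl leaving, could not show this outcome for nitro. Open, going by these compounds, is whether an amine or a carboxylic acid on this same carbon would read with compound 1 or with compound 4. No measurement among these compounds accounts for the shift, which stays unexplained.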